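Replacing a side chain with azetidin-1-yl

The compounds below may be only part of what the source reports. "The series", "measured", "known", "first", "only" and "open" are said of these compounds alone.

- Compound 1 `C=CCNC1=C2C[C@@H](C)C[C@H](OC)C(=O)[C@@H](C)/C=C(\C)[C@H](OC(N)=O)[C@@H](OC)/C=C\C=C(/C)C(=O)NC(=CC1=O)C2=O` gives 450 nM
- Compound 2 `CO[C@H]1C[C@H](C)CC2=C(NCCN(C)C)C(=O)C=C(NC(=O)/C(C)=C/C=C\[C@H](OC)[C@@H](OC(N)=O)/C(C)=C/[C@H](C)C1=O)C2=O` gives 100 nM
- Compound 3 `CO[C@H]1C[C@H](C)CC2=C(NCCN(C)C)C(=O)C=C(NC(=O)/C(C)=C/C=C\[C@H](OC)[C@@H](OC(N)=O)/C(C)=C/[C@H](C)/C1=N\OCC(=O)O)C2=O` gives 2700 nM

All three were tested in a functional assay on SK-BR-3 cells (Homo sapiens) for cytotoxicity, read by CellTiter-Glo, with a stated time of 72 h (a higher number here means a weaker inhibitor, a lower number a stronger inhibitor), and compound 2 has the lowest number of the three, ahead of compound 1 and well ahead of compound 3. The next compound to be measured is compound 4 `CO[C@H]1C[C@H](C)CC2=C(N3CCC3)C(=O)C=C(NC(=O)/C(C)=C/C=C\[C@H](OC)[C@@H](OC(N)=O)/C(C)=C/[C@H](C)C1=O)C2=O` which keeps the shared core of compound 2 and changes one group: azetidin-1-yl in place of (2-(dimethylamino)ethyl)amino on a double-bonded ring carbon in the words of the change, azetidin-1-yl in place of (2-(dimethylamino)ethyl)amino on a double-bonded ring carbon.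

Among the compounds with values here, only one measured step bears on this change. It is a 4.5-fold lower number from compound 1 to compound 2 (0.65 log units; beyond the scatter) and it too altered the group on this ring carbon. Compound 1 lacks the dimethylamino end of the chain, and compound 4 lacks it as well, so a modest move back towards a higher number is expected. Within the data shown here, no measured compound carries azetidin-1-yl, which makes this a rough guide, and compound 3 offers no step on this change.

The estimate is a 2.8-fold higher number from compound 2 to compound 4 (0.45 log units; beyond the scatter) as the expected size of the step in this assay here. For compound 4 the expected value is 280 nM with an estimated range from 80 nM to 1000 nM for repeated measurements.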

Compound 4, half-maximal inhibitory concentration: 260 nM
The estimate for compound 4 lay 1.1-fold (0.03 log units) above the measured number, within the range that was stated.
By their numbers in this assay, from the lowest: compound 2; then compounds 4 and 1 (each within the scatter of the next); then compound 3.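

In this assay, azetidin-1-yl in place of (2-(dimethylamino)ethyl)amino on this double-bonded ring carbon gives a 2.6-fold higher number from compound 2 to compound 4 (0.41 log units; beyond the scatter), so this position also accepts a small ring joined through its nitrogen, though at a cost compared with the chain in compound 2. Compared with the allylamino group of compound 1, azetidin-1-yl gives a 1.7-fold lower number from compound 1 to compound 4 (0.24 log units; within the scatter), so a ring and an open chain without the dimethylamino end cannot be told apart here, while compound 2 stands apart from both. No accompanying measurement explains these steps.

The change from compound 2 to compound 4 removes the amide-like amine hydrogen on this carbon and the dimethylamino end together, and it also closes a ring, so the step cannot say which of these matters. An azetidin-1-yl ring carrying a dimethylamino group, or a larger ring such as pyrrolidin-1-yl or morpholin-4-yl, would be needed on this carbon to begin separating those parts.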